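Chloro to bromo on the phenyl ring of compound 1

A few compounds are considered here, and "the series" means these few. Any claim that something is new, unique, unknown or untested is made for them only; others in the source may bear on it.

Measured so far:
- compound 1, `COc1ccccc1-n1c(Nc2nc(-c3ccc(Cl)cc3)cs2)n[nH]c1=S`: 100 mg/kg
- compound 2, `Cc1ccccc1-n1c(Nc2nc(-c3ccc(Cl)cc3)cs2)n[nH]c1=S`: 100 mg/kg

Of the compounds shown here, two built on a shared core have been tested in a functional assay on the whole organism (strain Swiss albino) for inhibition, with Mus musculus as the target, with a stated time of 0.5 h; a higher number here means that more compound is needed for the effect, a lower number that less compound is needed. Compound 1 gives 100 mg/kg in this assay, and compound 2 gives 100 mg/kg. Among the measured compounds shown here, the single measured step, no change at the digits printed from compound 1 to compound 2 (within the scatter), shows that swapping methyl for methoxy on an aromatic carbon left the dose unchanged within the scatter, so compound 1 stands level with compound 2.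

Compound 3, `COc1ccccc1-n1c(Nc2nc(-c3ccc(Br)cc3)cs2)n[nH]c1=S`, is not yet measured. Compared with compound 1 it differs in one place: bromo in place of chloro on an aromatic carbon. For the measured compounds named here, no measured step touches this part of the molecule, so the only guide is the overall flatness seen from compound 1 to compound 2. The change is expected to shift this assay by little or nothing beyond the scatter, no change at the digits printed from compound 1 to compound 3 (within the scatter). For compound 3 the expected value is therefore 100 mg/kg, within a range from 50 mg/kg to 200 mg/kg.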

Compound 3, minimum effective dose: 300 mg/kg
Estimate against measurement, compound 3: 3.0-fold (0.48 log units) below; the whole stated range lies below it.
By their numbers in this assay, from the lowest: compounds 1 and 2 (each within the scatter of the next); then compound 3.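

The group at the end of the 4-chlorophenyl part of compound 1 is not a silent spot. In this assay, bromo in place of chloro on this aromatic carbon gives a clear shift (a 3.0-fold higher number from compound 1 to compound 3 (0.48 log units; beyond the scatter)), so more compound is needed for the effect. The earlier swap of methyl for methoxy elsewhere in the molecule stayed within the scatter (no change at the digits printed from compound 1 to compound 2 (within the scatter)), whereas this modest step goes beyond it, and nothing measured here explains the difference between the two halogens.

On these data alone, it remains open how the dose responds to other groups at this place, such as fluoro, an amine or a carboxylic acid. As far as these compounds go, it is also open whether the same change from chloro to bromo has a similar effect on compound 2, which carries methyl instead of methoxy.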